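Diaryl urea series: aminopyrimidine aryl variation, cell growth inhibition

The source may report more compounds than this note shows. Statements on the series, on what has been measured and on what is new or still open speak of the compounds shown alone.

Measured compounds:
compound 1 `COc1cc(NC(=O)Nc2cc(Nc3cccc(C(C)(C)C)c3)ncn2)cc(OC)c1`, 35.1%
compound 2 `COc1cc(NC(=O)Nc2cc(Nc3ccc(OC)c(I)c3)ncn2)cc(OC)c1`, 43%

In a functional assay on NCI-H1581 cells (Homo sapiens) for inhibition, read by MTT assay, with a stated time of 48 h, tested at 10 uM (a lower number here means less inhibition, a higher number more inhibition at the concentration tested (going by the name of the read-out)), compound 1 gives 35.1%. In this assay compound 2 gives 43%, which is the higher of the two numbers at hand, though the gap to compound 1 is within the scatter: a number 7.9 percentage points higher from compound 1 to compound 2 (within the scatter).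

Compound 3 `COc1cc(NC(=O)Nc2cc(Nc3ccc(C)c(C)c3)ncn2)cc(OC)c1` is not yet measured. Its change from compound 2 is 3,4-dimethylphenyl in place of 3-iodo-4-methoxyphenyl on a nitrogen on an aromatic ring. For the measured compounds named here, the one measured step that bears on it, a number 7.9 percentage points higher from compound 1 to compound 2 (within the scatter), also swaps the aryl group on that same ring nitrogen, and it stayed within the scatter. A second such swap on the same position is therefore expected to move this assay little in either direction, with no step beyond the scatter predicted; the expected step is a number 5 percentage points lower from compound 2 to compound 3 (within the scatter).

For compound 3 the estimate in this assay is 38%, with a range from 22% to 54%.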

Compound 3, a percentage reported as inhibition, at one concentration (the size of the read-out at that concentration, not a potency): 20.1%
Estimate against measurement, compound 3: 17.9 percentage points above; measured number outside the range, below it.
By their numbers in this assay, from the lowest: compound 3; then compounds 1 and 2 (each within the scatter of the next).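

In this assay, the aryl group on this nitrogen can move the number beyond the scatter, which the earlier swap at this place did not show: the step is a number 22.9 percentage points lower from compound 2 to compound 3 (beyond the scatter), and the second step is a number 15 percentage points lower from compound 1 to compound 3 (beyond the scatter). The 3,4-dimethylphenyl group therefore stands apart from both 3-iodo-4-methoxyphenyl and 3-(tert-butyl)phenyl, which remain within the scatter of each other, and since the aryl group of compound 1 also carries neither iodine nor oxygen, the absence of those atoms does not by itself go with the lower number. No measurement at hand bears on the reason for either step.

On these data alone, the change from compound 2 to compound 3 replaces the iodine and the methoxy together, so their separate contributions stay open; a 3-iodophenyl or a 4-methoxyphenyl group on the same nitrogen would separate them. Also open, as far as these compounds go, is how the number in this assay would respond to a dimethylamino group or a carboxylic acid on this aryl ring.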